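Biaryl tail: pyridyl in place of trifluoromethylphenyl

The source may hold more compounds than are shown below. What is called first, only, known or untested is meant among the compounds shown, and "the series" means these compounds.

Compound 1 `CCOc1ccccc1-c1ccc(-c2nc3cnccc3c(N[C@H](CC)C(N)=O)c2C#N)cc1` and compound 2 `CC[C@@H](Nc1c(C#N)c(-c2ccc(-c3ccccc3C(F)(F)F)cc2)nc2cnccc12)C(N)=O` share one core and differ only at a single aromatic carbon of the outer ring. In a physicochemical assay for lipophilicity, read by HPLC, at pH 7.5 (a higher number here means a more lipophilic compound, a lower number a more polar compound), compound 1 gives 3, and compound 2 gives 3.1. The step of a number 0.10 log units higher from compound 1 to compound 2 (within the scatter). On this assay compound 2 and compound 1 sit within the scatter of each other, so neither can be set apart from the other.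

Compound 3 `CC[C@@H](Nc1c(C#N)c(-c2ccc(-c3ccncc3C)cc2)nc2cnccc12)C(N)=O` is not yet measured. It differs from compound 2 in one place: 3-methylpyridin-4-yl in place of 2-(trifluoromethyl)phenyl on an aromatic carbon.

Among the compounds with values here, the one measured step, a number 0.10 log units higher from compound 1 to compound 2 (within the scatter), swapped one substituent for another on the outer ring and stayed within the scatter; it does not cover an exchange of the whole outer ring, and no measured pair does. What can be said of compound 3 rests on that structural change alone. A step in this assay is expected to be well beyond the scatter and downward, estimated as a number 1.20 log units lower from compound 2 to compound 3 (beyond the scatter). Compound 3 is therefore expected to give about 1.9, within a range from 1.3 to 2.5.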

Compound 3, distribution coefficient: 2
Estimate against measurement, compound 3: 0.10 log units below, and the stated range covers the measured number.
By their numbers in this assay, from the lowest: compound 3; then compounds 1 and 2 (each within the scatter of the next).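

In this assay the choice of outer ring at this position moves the number where the choice of substituent on that ring did not: 3-methylpyridin-4-yl in place of 2-(trifluoromethyl)phenyl gives a number 1.10 log units lower from compound 2 to compound 3 (beyond the scatter) and in place of 2-ethoxyphenyl gives a number 1.00 log units lower from compound 1 to compound 3 (beyond the scatter) whereas trifluoromethyl in place of ethoxy gave only a number 0.10 log units higher from compound 1 to compound 2 (within the scatter) on the same ring. Both steps into compound 3 lie beyond the scatter, so compound 3 stands apart from compound 1 and from compound 2 on this scale, whichever of the two carbon-only rings it is set against. No measurement at hand accounts for the shift.

Compound 3 differs from compound 2 in both the ring hetero atom and the substituent, methyl against trifluoromethyl, so these compounds cannot divide the step between the two changes; a plain pyridin-4-yl or a 2-methylphenyl ring at this carbon would bear on that. On these data alone, how the number responds to a basic amine or a carboxylic acid on the outer ring, or to a longer chain in place of the methyl, also stays open.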